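A few compounds are considered here, and "the series" means these few. Any claim that something is new, unique, unknown or untested is made for them only; others in the source may bear on it.

Compound 1 `O=C(Nc1ccccc1[N+](=O)[O-])N[C@H]1CC[C@H](Oc2ccc(F)cc2)CC1` gives 3500 nM in a functional assay on CRL2813 cells (Homo sapiens) for cytotoxicity, read by sulforhodamine B assay, with a stated time of 5 days; on this read-out higher numbers stand for weaker inhibition and lower numbers for stronger inhibition.
Compound 2 `O=C(Nc1ccc(Cl)cc1)N[C@H]1CC[C@H](Oc2ccc(F)cc2)CC1` gives only a limit of this assay, > 20000 nM.
Compound 3 `O=C(Nc1ccccc1Br)N[C@H]1CC[C@H](Oc2ccc(F)cc2)CC1` gives 7700 nM.

Among the numbers shown, compound 3 stands highest, with compound 1 the nearest and lower, a 2.2-fold higher number from compound 1 to compound 3 (0.34 log units; beyond the scatter). Compound 2 sits at the limit, (the limit of > 20000 nM in this assay, at which 1 of the 3 values shown sits), so its gap to compound 3 is known only as an at least 2.5-fold lower number from compound 2 to compound 3 (0.41 log units; beyond the scatter).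

Compound 4 `COc1ccccc1NC(=O)N[C@H]1CC[C@H](Oc2ccc(F)cc2)CC1` differs from compound 3 by methoxy in place of bromo on an aromatic carbon. Going by the values given here, the only measured step at this same carbon, nitro to bromo, was a 2.2-fold higher number from compound 1 to compound 3 (0.34 log units; beyond the scatter), a modest change. A further swap of a small group at this place is therefore expected to move the number little, if at all, in either direction.

Compound 4 is expected to give about 7000 nM, between 2500 nM and 20000 nM, a step of a 1.1-fold lower number from compound 3 to compound 4 (0.04 log units; within the scatter).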

Compound 4, half-maximal inhibitory concentration: > 20000 nM
Compound 4: no number, only a limit (the forecaster's own chance of this, stated with the estimate: 20%); middle value at least 2.8-fold (0.45 log units) from the limit.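

Compound 4 gives no number, only a limit: the limit of > 20000 nM in this assay, at which 2 of the 4 values shown sit. At this aromatic carbon a small swap therefore matters more than the nitro-to-bromo step suggested: methoxy in place of bromo gives an at least 2.5-fold higher number from compound 3 to compound 4 (0.41 log units; beyond the scatter), and methoxy in place of nitro gives an at least 5.7-fold higher number from compound 1 to compound 4 (0.75 log units; beyond the scatter). The step between compound 2 and compound 4 cannot be read, as both values are limits.

Still open, going by these compounds, is whether an amine or a carboxylic acid at this carbon would give a lower number than nitro does. On these data alone, the true values of compound 2 and compound 4 also remain unknown.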